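The source may hold more compounds than are shown below. What is called first, only, known or untested is meant among the compounds shown, and "the series" means these compounds.

Compound 1 (`CCOC(=O)C(=O)CC(=O)/C=C/c1cn(CC(=O)N2CCOCC2)c2ccccc12`) gives "not determined" (no result reported) in an ADME assay on HeLa cells (Homo sapiens) for inhibition, read by MTT assay, with a stated time of 48 h; a higher number here means a weaker inhibitor, a lower number a stronger inhibitor
Compound 2 (`O=C(/C=C/c1cn(-c2ccc(Cl)cc2)c2ccccc12)CC(=O)C(=O)O`) gives > 40000 nM in this assay and this is a limit
Compound 3 (`COc1ccc(Cn2cc(/C=C/C(=O)CC(=O)C(=O)O)c3ccccc32)cc1`) gives > 40000 nM in this assay and this is a limit

Compound 3 therefore stands at a limit and not at a number. Within the data shown here, the series so far rests on the limit of > 40000 nM in this assay, at which 2 of the 3 values shown sit, and compound 1 adds no result.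

Compound 4 (`O=C(/C=C/c1cn(CC(=O)N2CCOCC2)c2ccccc12)CC(=O)C(=O)O`) differs from compound 3 by (morpholin-4-yl)carbonyl in place of 4-methoxyphenyl on a saturated chain carbon bound to an aromatic nitrogen with (morpholin-4-yl)carbonyl in place of 4-methoxyphenyl on a saturated chain carbon bound to an aromatic nitrogen.

Among the measured compounds shown here, with a step that the two limits leave unreadable from compound 2 to compound 3 as the only measured step at a group on the aromatic nitrogen, there is no size to carry over. The expected size of a number no higher from compound 3 to compound 4 (the limit leaves the size open) is nothing beyond the usual scatter, in no set direction, and another limit in this assay is the likeliest report. For compound 4 the estimated value is 40000 nM with an expected range of 15000 nM to 80000 nM as its span.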

Compound 4, half-maximal inhibitory concentration: > 40000 nM
Compound 4: only a limit was reported; the forecaster's own chance of this, stated with the estimate: 80%; the middle value lies on the limit itself.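

Compound 2, compound 3 and compound 4 all report only a limit in this assay, so no step among them can be read: the limit of > 40000 nM in this assay, at which 3 of the 4 values shown sit.

The compounds shown leave open whether any group on the aromatic nitrogen gives a numerical half-maximal inhibitory concentration in this assay.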